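The source may report more compounds than this note shows. Statements on the series, on what has been measured and on what is new or still open speak of the compounds shown alone.

Measured so far:
Compound 1, `CCC(CC)(c1ccc(OCCCCCO)c(C)c1)c1ccc(OCC(O)C(C)(C)C)c(OCC(O)C(C)(C)C)c1` — 67%
Compound 2, `CCC(CC)(c1ccc(OCCCCCCCO)c(C)c1)c1ccc(OCC(O)C(C)(C)C)c(OCC(O)C(C)(C)C)c1` — 5%
Compound 3, `CCC(CC)(c1ccc(OS(=O)(=O)c2ccccc2)c(C)c1)c1ccc(OCC(O)C(C)(C)C)c(OCC(O)C(C)(C)C)c1` — "not active" (no number reported)

In an assay on cells for binding affinity to vitamin D3 receptor (Homo sapiens), read by fluorescence, tested at 1 uM (on this read-out lower numbers stand for less inhibition and higher numbers for more inhibition at the one concentration tested (going by the name of the read-out)), compound 1 gives 67%. Compound 2 carries a longer hydroxyalkyl chain, and in this assay compound 2 gives 5%; the step of a number 62 percentage points lower from compound 1 to compound 2 (beyond the scatter) is a large drop. Compound 3 replaces the hydroxyalkyl chain with a phenylsulfonyl group; in this assay compound 3 is reported as "not active" (no number reported), with no number attached, so compound 3 stands at the bottom of the three without a figure of its own.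

Compound 4, `CCC(CC)(c1ccc(OS(=O)(=O)c2ccc([N+](=O)[O-])cc2)c(C)c1)c1ccc(OCC(O)C(C)(C)C)c(OCC(O)C(C)(C)C)c1`, is not yet measured. It differs from compound 3 in one place: nitro in place of hydrogen on an aromatic carbon. Going by the values given here, no measured step among the three compounds touches this kind of change; the only step in the set, from compound 1 to compound 2, concerns the hydroxyalkyl chain, not the sulfonyl phenyl, so it gives no direct guide. What is known is only that the parent, compound 3, showed nothing in this assay. On that basis compound 4 is expected to stay low in this assay as well, with an estimated 10%, in a range from 0% to 35%, and a fair chance that only "not active" is reported again.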

Compound 4, a percentage reported as inhibition, at one concentration (the size of the read-out at that concentration, not a potency): 29%
Beside the measured number, compound 4's estimate is 19 percentage points below it, and the stated range covers the measured number.
By their numbers in this assay, from the lowest: compound 2; then compound 4; then compound 1.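

In this assay compound 4 gives 29%, so with nitro on the aromatic carbon para to a large group, the sulfonyl series now has a figure, whereas its phenylsulfonyl parent, compound 3, was reported only as "not active"; the step between those two cannot be read as a number. The (4-nitrophenyl)sulfonyl group on the oxygen on the aromatic ring also compares in both directions with the hydroxyalkyl chains, with a number 24 percentage points higher from compound 2 to compound 4 (beyond the scatter) against 7-hydroxyheptyl and a number 38 percentage points lower from compound 1 to compound 4 (beyond the scatter) against 5-hydroxypentyl, placing it between the two chains in this assay. Nothing available explains why the nitro compound reads as it does.

The compounds shown leave open whether this reading is specific to nitro or would also appear with an amine, a carboxylic acid or a methoxy group on the same aromatic carbon. They also leave open how a 6-hydroxyhexyl chain on that oxygen would compare, and, with only one concentration tested, what the potency of compound 4 is.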